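This account rests on a few compounds, and the source may have more. Where it says the series, first, only, none or still open, it means among the compounds named here.

Compound 1 `COC1=C(C)C(=O)/C(=C(O)/C=C/c2ccc(Br)cc2)C(=O)C1(C)C`: 17.7 ug/mL
Compound 2 `COC1=C(C)C(=O)/C(=C(O)/C=C/c2ccccc2OC)C(=O)C1(C)C`: 15.6 ug/mL

Both values come from a functional assay on PC-3 cells (Homo sapiens) for cytotoxicity; on this read-out higher numbers stand for an effect only at larger amounts of compound and lower numbers for an effect already at smaller amounts. For the measured compounds named here, with only two compounds measured, compound 1 has a single neighbour, compound 2, and the two cannot be told apart: a 1.1-fold lower number from compound 1 to compound 2 (0.05 log units; within the scatter). That step puts 2-methoxyphenyl in place of 4-bromophenyl on an otherwise shared structure.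

Compound 3 `COC1=C(C)C(=O)/C(=C(O)/C=C/c2ccc(O)cc2)C(=O)C1(C)C` has not been measured yet. It differs from compound 1 in one place: hydroxy in place of bromo on an aromatic carbon. This is hydroxy in place of bromo on an aromatic carbon, para to a large group, so 4-bromophenyl becomes 4-hydroxyphenyl.

Going by the values given here, only one measured step bears on this change, and only loosely. Compound 2 also loses the 4-bromophenyl group of compound 1, and the result was a 1.1-fold lower number from compound 1 to compound 2 (0.05 log units; within the scatter). Among the compounds with values here, no measured compound carries a hydroxy group, so the evidence is thin and a surprise in either direction remains possible. Even so, no shift beyond the scatter is expected in this assay. The expected step is a 1.1-fold lower number from compound 1 to compound 3 (0.04 log units; within the scatter). Compound 3 is estimated at 16 ug/mL, with an expected range of 7 ug/mL to 36 ug/mL.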

Compound 3, concentration for half-maximal effect: > 20 ug/mL
Compound 3: no number, only a limit; the forecaster's own chance of this, stated with the estimate: 10%; middle value at least 1.2-fold (0.09 log units) from the limit.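

In this assay compound 3 gives > 20 ug/mL, which is a limit of the assay and not a number. The two new steps can therefore be stated only as floors: an at least 1.1-fold higher number from compound 1 to compound 3 (0.05 log units; that floor lies within the scatter), and an at least 1.2-fold higher number from compound 2 to compound 3 (0.10 log units; that floor lies within the scatter). This is the first hint that the group at this position may matter, since 4-hydroxyphenyl gives only a limit where 4-bromophenyl and 2-methoxyphenyl both give numbers, but both floors lie within the scatter, so a real change is not shown.

The true value of compound 3 stays open, and the only fact available is where the reading stops: the limit of > 20 ug/mL in this assay, at which 1 of the 3 values shown sits. The compounds shown also do not tell how an amine, a carboxylic acid or a fluoro group on this same aromatic carbon would read, or whether the result depends on hydroxy entering or on bromo leaving.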